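The source may report more compounds than this note shows. Statements on the series, on what has been measured and on what is new or still open speak of the compounds shown alone.

Compound 2 `CCNc1ncc(C(=O)O)c2nc(-c3ccco3)nn12` gives the higher of the two numbers recorded in an assay on CHO cells for displacement of a labelled ligand from adenosine receptor A3 (Homo sapiens) (a higher number here means a weaker inhibitor, a lower number a stronger inhibitor), namely 480 nM; compound 1 `CCOC(=O)c1cnc(NC2CC2)n2nc(-c3ccco3)nc12` gives 9.52 nM in this assay, and the two structures differ in more than one place. Compound 3 `O=C(O)c1cnc(NCc2ccc(Cl)cc2)n2nc(-c3ccco3)nc12` follows from compound 2 by 4-chlorophenyl in place of methyl on a saturated chain carbon bound to a nitrogen on an aromatic ring. Among the compounds with values here, no measured pair carries this change, so the direction is uncertain; the step is expected to be a moderate move toward a lower number, a 3.2-fold lower number from compound 2 to compound 3 (0.51 log units; beyond the scatter), with wide error. Compound 3 is estimated at 150 nM, with a range from 30 nM to 800 nM.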

Compound 3, inhibition constant: 11600 nM
Compound 3: the middle estimate sits 77-fold (1.89 log units) below what was measured, outside the stated range (above it).
By their numbers in this assay, from the lowest: compound 1; then compound 2; then compound 3.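

On the saturated chain carbon bound to a nitrogen on an aromatic ring, 4-chlorophenyl in place of methyl gives a 24-fold higher number from compound 2 to compound 3 (1.38 log units; beyond the scatter) in this assay. This first single-place step in the series shows that, with the carboxylic acid kept, ethyl to 4-chlorobenzyl costs much of the inhibition. Nothing at hand explains this loss.

Still open, from the compounds shown here alone, is whether an unsubstituted benzyl or a longer alkyl chain at this position stays closer to ethyl. Also open, going by these compounds, is whether 4-chlorobenzyl gives the same loss with an ethyl ester in place of the carboxylic acid.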